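Removing one fluoro from the aryl ether of compound 3

The source may hold more compounds than are shown below. What is called first, only, known or untested is meant among the compounds shown, and "the series" means these compounds.

In an assay on cells (Hepatocyte, strain Sprague-Dawley) for inhibition of acyl-CoA desaturase 1 (Rattus norvegicus), read by HPLC (a lower number here means a stronger inhibitor, a higher number a weaker inhibitor), compound 3 `O=C(O)c1cncc(-c2ccc(N3CCC(Oc4cc(F)c(F)cc4Br)CC3)nn2)c1` gives 563 nM, compound 2 `O=C(O)c1cncc(-c2ccc(N3CCC(Oc4ccccc4I)CC3)nn2)c1` gives 1000 nM and compound 1 `O=C(O)c1cncc(-c2ccc(N3CCC(Oc4ccccc4Br)CC3)nn2)c1` gives 1640 nM. Among the compounds with values here, compound 3 holds the lowest of the three numbers, but only the step of a 2.9-fold lower number from compound 1 to compound 3 (0.46 log units; beyond the scatter) lies beyond the scatter, while a 1.8-fold lower number from compound 2 to compound 3 (0.25 log units; within the scatter) and a 1.6-fold lower number from compound 1 to compound 2 (0.21 log units; within the scatter) do not. Compound 4 `O=C(O)c1cncc(-c2ccc(N3CCC(Oc4cc(F)ccc4Br)CC3)nn2)c1` differs from compound 3 by hydrogen in place of fluoro on an aromatic carbon. Within the data shown here, the step of a 2.9-fold lower number from compound 1 to compound 3 (0.46 log units; beyond the scatter) is the one that bears on this, and it introduced both fluoro groups together; no measured step removes one alone. For compound 4 a step of a 1.5-fold higher number from compound 3 to compound 4 (0.18 log units; within the scatter) is expected, toward a higher number, giving back part of that gain. Compound 4 is estimated at 850 nM, within a range of 400 nM to 1700 nM.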

Compound 4, half-maximal inhibitory concentration: 175 nM
For compound 4 the middle estimate is 4.9-fold (0.69 log units) above the measured one; the measured number lies below the stated range.
By their numbers in this assay, from the lowest: compound 4; then compounds 3, 2 and 1 (each within the scatter of the next, the first and the last beyond it).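

Hydrogen in place of fluoro at the carbon para to a large group lowers the number (a 3.2-fold lower number from compound 3 to compound 4 (0.51 log units; beyond the scatter)), so the two fluoro groups of compound 3 do not contribute alike. The 2-bromo-5-fluorophenyl ring, with its single fluoro, gives a larger step from the unfluorinated ring (a 9.4-fold lower number from compound 1 to compound 4 (0.97 log units; beyond the scatter)) and also stands clear of the iodo analogue (a 5.7-fold lower number from compound 2 to compound 4 (0.76 log units; beyond the scatter)). No measurement available here explains this reversal.

From the compounds shown here alone, whether a nitrile or a methoxy group in place of the remaining fluoro keeps the low number stays open. Also open, going by these compounds, is whether the 2-iodophenyl ring responds to that fluoro in the same way.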